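A few compounds are considered here, and "the series" means these few. Any claim that something is new, unique, unknown or untested is made for them only; others in the source may bear on it.

Compound 1, `COC(=O)N[C@H](C(=O)NN(CCC[C@@](O)(Cc1ccccc1)C(=O)N[C@H]1c2ccccc2C[C@H]1O)Cc1ccc(Br)cc1)C(C)(C)C`, gives in an ADME assay on MT4 cells (Homo sapiens) for cytotoxicity (on this read-out higher numbers stand for lower toxicity in this test and lower numbers for higher toxicity in this test), a value of > 10000 nM, which is a limit of the assay.
Compound 2, `COC(=O)N[C@H](C(=O)NN(CCC[C@@](O)(Cc1ccccc1)C(=O)N[C@H]1c2ccccc2C[C@H]1O)Cc1ccc(-c2nc(C(C)(C)C)cs2)cc1)C(C)(C)C`, gives in this assay a value of > 10000 nM, also a limit.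
Compound 3, `COC(=O)N[C@H](C(=O)NN(CCC[C@@](O)(Cc1ccccc1)C(=O)N[C@H]1c2ccccc2C[C@H]1O)Cc1ccc(-c2cn3ccsc3n2)cc1)C(C)(C)C`, gives in this assay a value of > 10000 nM, again a limit.

Compound 1 therefore stands only at a limit in this assay, and the two further values shown sit at the limit of > 10000 nM in this assay, at which 3 of the 3 values shown sit. The change from compound 1 to compound 4, `COC(=O)N[C@H](C(=O)NN(CCC[C@@](O)(Cc1ccccc1)C(=O)N[C@H]1c2ccccc2C[C@H]1O)Cc1ccc(OCc2cnc(Cl)s2)cc1)C(C)(C)C`, is (2-chloro-1,3-thiazol-5-yl)methoxy in place of bromo on an aromatic carbon. The measured steps that bear on it are the two that likewise exchange the bromo group on this aromatic carbon: a step that the two limits leave unreadable from compound 1 to compound 2 and a step that the two limits leave unreadable from compound 1 to compound 3. Neither can be read in size because of the limit of > 10000 nM in this assay, at which 3 of the 3 values shown sit; they show only that each replacement left toxicity outside the measurable range. The comparison a step that the two limits leave unreadable from compound 2 to compound 3 adds nothing beyond that. For compound 4 an outcome at or past the same limit is accordingly expected, with no readable step in either direction. The estimate for compound 4 in this assay is 15000 nM, expected to lie between 8000 nM and 40000 nM. The step this estimate implies, a step that the limit leaves unreadable from compound 1 to compound 4, is expected to stay unreadable, as the others did.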

Compound 4, half-maximal cytotoxic concentration: > 10000 nM
Compound 4: no number, only a limit; the forecaster's own chance of this, stated with the estimate: 85%; the middle value is on the limit's open side.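

Compound 4 also stands only at a limit in this assay, so its steps from compound 1, compound 2 and compound 3 cannot be read: the limit of > 10000 nM in this assay, at which 4 of the 4 values shown sit.

The compounds shown leave open how far any of compound 1, compound 2, compound 3 and compound 4 lies beyond that limit, and whether their groups on the aromatic carbon differ at all in this assay.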